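Extending the Side Chain on a Quinoline-Free Description of Two Analogues

A few compounds are considered here, and "the series" means these few. Any claim that something is new, unique, unknown or untested is made for them only; others in the source may bear on it.

Compound 2 `CCCc1cc2ccccc2nc1-c1cc(-c2ccc(C(F)(F)F)cc2)no1` is the only one of the two measured compounds that gives an actual number in a functional assay on A549 cells (Homo sapiens) for inhibition, read by MTT assay, with a stated time of 24 h; on this read-out lower numbers stand for stronger inhibition and higher numbers for weaker inhibition: it comes out at 43900 nM. Compound 1 `CCCCCc1cc2ccccc2nc1-c1cc(-c2ccc(C)cc2)no1` gives only a limit of the assay, > 100000 nM, which is the point described by the limit of > 100000 nM in this assay, at which 1 of the 2 values shown sits. Compound 3 `CCCCCc1cc2ccccc2nc1-c1cc(-c2ccc(C(F)(F)F)cc2)no1` has not been measured; it differs from compound 2 by ethyl in place of hydrogen on a saturated chain carbon, three bonds along the chain from an aromatic carbon, so that propyl becomes pentyl. Among the compounds with values here, no measured pair shows this step, and compound 1, which also carries the pentyl chain, differs from compound 3 in another place as well, so its value can only be noted, not used as a step. The expected step from compound 2 to compound 3, a 1.6-fold higher number from compound 2 to compound 3 (0.20 log units; within the scatter), runs toward weaker inhibition, beyond the usual scatter. Compound 3 is therefore estimated at 70000 nM, with a range from 20000 nM to 200000 nM.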

Compound 3, half-maximal inhibitory concentration: 28300 nM
Compound 3: middle estimate off by 2.5-fold (0.39 log units), on the high side; the range from low to high includes it.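

Going from propyl to pentyl on this chain moves the number in this assay very little, with a 1.6-fold lower number from compound 2 to compound 3 (0.19 log units; within the scatter) as the step, so at this position the added ethyl does nothing that can be told apart from repeat measurements. The two compounds that share the pentyl chain give the first clear difference, with an at least 3.5-fold lower number from compound 1 to compound 3 (0.54 log units; beyond the scatter) as the step for trifluoromethyl in place of methyl on an aromatic carbon. Compound 1 stands at a limit of the assay, not at a number: the limit of > 100000 nM in this assay, at which 1 of the 3 values shown sits.

On these data alone, whether a longer chain such as heptyl, or an amine at the end of the chain, would shift the number remains open. Also open, as far as these compounds go, is whether the change from methyl to trifluoromethyl would give a step of similar size on the propyl chain.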